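The source may report more compounds than this note shows. Statements on the series, on what has been measured and on what is new or still open speak of the compounds shown alone.

Within the data shown here, in a functional assay on MCF7 cells (Homo sapiens) for antiproliferative activity (a higher number here means a weaker inhibitor, a lower number a stronger inhibitor), three compounds sharing one core have numbers so far. Compound 1 `O=C(Nc1ccc(O)c2c(=O)cc(-c3ccccc3Cl)oc12)c1ccccc1`, which carries a benzamido group, gives 7100 nM. Compound 2 `O=c1cc(-c2ccccc2Cl)oc2c(N3CCCC3)ccc(O)c12`, with pyrrolidin-1-yl in that place, gives 20000 nM, and compound 3 `O=c1cc(-c2ccccc2Cl)oc2c(N3CCCCC3)ccc(O)c12`, with piperidin-1-yl, gives 17000 nM. Compound 3 thus sits within the scatter of compound 2, as a 1.2-fold lower number from compound 2 to compound 3 (0.07 log units; within the scatter) shows, and is a weaker inhibitor than compound 1.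

Compound 4 `CCC(C)OC(=O)Nc1ccc(O)c2c(=O)cc(-c3ccccc3Cl)oc12` has (sec-butoxycarbonyl)amino in place of piperidin-1-yl on an aromatic carbon, para to a hydroxy group ((sec-butoxycarbonyl)amino in place of piperidin-1-yl on an aromatic carbon). The nearest guide is compound 1, whose benzamido group also joins the core through a nitrogen bearing a carbonyl. Leaving that group for a ring gave a 2.4-fold higher number from compound 1 to compound 3 (0.38 log units; beyond the scatter) and a 2.8-fold higher number from compound 1 to compound 2 (0.45 log units; beyond the scatter), both modest but beyond the scatter. Going from the ring back to a nitrogen bearing a carbonyl should therefore run the other way, although no group with the sec-butoxy part has been measured. A modest step towards a lower number is expected in this assay, estimated as a 1.9-fold lower number from compound 3 to compound 4 (0.28 log units; within the scatter). For compound 4 the estimated value is 9000 nM, with an expected range from 3500 nM to 22000 nM.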

Compound 4, half-maximal inhibitory concentration: 30000 nM
For compound 4 the middle estimate is 3.3-fold (0.52 log units) below the measured one; measured number above the stated range.
By their numbers in this assay, from the lowest: compound 1; then compounds 3, 2 and 4 (each within the scatter of the next).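

In this assay, compound 4 keeps the nitrogen bearing a carbonyl found in compound 1, yet it cannot be told apart from the two compounds with a ring at this position: a 1.8-fold higher number from compound 3 to compound 4 (0.25 log units; within the scatter) and a 1.5-fold higher number from compound 2 to compound 4 (0.18 log units; within the scatter). The nitrogen bearing a carbonyl is therefore not enough on its own to set a compound apart from the ring compounds, and the group on the carbonyl carbon also counts, since sec-butoxy in place of phenyl gives a 4.2-fold higher number from compound 1 to compound 4 (0.63 log units; beyond the scatter). The data offer no measurement that would explain why the phenyl and sec-butoxy compounds differ.

Among these compounds, compound 1 remains the only compound that stands apart, so a single phenyl example carries the whole difference, and it is open whether an acetamido group, a 4-fluorobenzamido group or a phenoxycarbonylamino group would stay with compound 1 or join the others. On these data alone, it is equally open whether the carbonyl is needed at all, which a free amine or a benzylamino group at this position could test.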